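From anilino to ethylamino on a shared core

The source may report more compounds than this note shows. Statements on the series, on what has been measured and on what is new or still open speak of the compounds shown alone.

Among the compounds with values here, in a functional assay on SK-OV-3 cells (Homo sapiens) for cytotoxicity, read by MTT assay, with a stated time of 3 days (a lower number here means a stronger inhibitor, a higher number a weaker inhibitor), compound 1 (`N#Cc1c(Cl)nc(SCc2nc3ccccc3[nH]2)nc1-c1ccccc1`) gives 3.37 nM and compound 2 (`N#Cc1c(Nc2ccccc2)nc(SCc2nc3ccccc3[nH]2)nc1-c1ccccc1`) gives 4.46 nM, so compound 2 stands within the scatter of compound 1, the only other number known. Compound 3 (`CCNc1nc(SCc2nc3ccccc3[nH]2)nc(-c2ccccc2)c1C#N`) keeps the core of compound 2 but carries ethyl in place of phenyl on a nitrogen on an aromatic ring. Within the data shown here, the one measured step that bears on this, anilino in place of chloro (a 1.3-fold higher number from compound 1 to compound 2 (0.12 log units; within the scatter)), stayed within the scatter, so no step beyond the scatter is expected in this assay here. The estimated step is a 1.0-fold higher number from compound 2 to compound 3 (0.00 log units; within the scatter) at its middle. Compound 3 is estimated at 4.5 nM with 1.5 nM to 14 nM as the expected range.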

Compound 3, half-maximal inhibitory concentration: 7.35 nM
Estimate against measurement, compound 3: 1.6-fold (0.21 log units) below, within the range that was stated.
By their numbers in this assay, from the lowest: compounds 1, 2 and 3 (each within the scatter of the next, the first and the last beyond it).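

In this assay the anilino group gives way to ethylamino with a 1.6-fold higher number from compound 2 to compound 3 (0.22 log units; within the scatter) and so a nitrogen substituent without any ring stays within the scatter of the phenyl one. Within the data shown here, measured against chloro, however, ethylamino shows a 2.2-fold higher number from compound 1 to compound 3 (0.34 log units; beyond the scatter) and this modest step is the first at this position to pass the scatter. No measurement available here accounts for either step.

Still open, on these data alone, is how a longer chain on this nitrogen, such as butyl, or a ring amine such as morpholine in place of ethylamino, would read in this assay at this position.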